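Compound 2 to compound 3: anilino to (4-chlorophenyl)amino

This account rests on a few compounds, and the source may have more. Where it says the series, first, only, none or still open, it means among the compounds named here.

In an ADME assay on MT4 cells (Homo sapiens) for cytotoxicity, read by MTT assay, with a stated time of 96 h (a lower number here means that less compound is tolerated, a higher number that more compound is tolerated), compound 1 (`Cc1ccc(NCc2cn(-c3ccccc3)nc2-c2ccc(C)cc2)cc1`) gives > 100000 nM as a limit of the assay. Compound 2 (`Cc1ccc(-c2nn(-c3ccccc3)cc2CNc2ccccc2)cc1`) gives > 100000 nM as a limit too. Compound 3 (`Cc1ccc(-c2nn(-c3ccccc3)cc2CNc2ccc(Cl)cc2)cc1`) carries chloro in place of hydrogen on an aromatic carbon as its change, chloro in place of hydrogen on an aromatic carbon, para to a large group. Among the measured compounds shown here, the only measured step, a step that the two limits leave unreadable from compound 1 to compound 2 in size, offers nothing to carry over, and the limit of > 100000 nM in this assay, at which 2 of the 2 values shown sit, is all that bears on the change. A modest downward step or none is expected in this assay here. The estimated step is an at least 1.2-fold lower number from compound 2 to compound 3 (0.09 log units; that floor lies within the scatter) at this stage. For compound 3 the expected value is 80000 nM with 35000 nM to 100000 nM as the estimated range.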

Compound 3, half-maximal cytotoxic concentration: > 100000 nM
Compound 3: a limit, no number; the forecaster's own chance of this, stated with the estimate: 60%; at least 1.2-fold (0.09 log units) between middle value and limit.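

In this assay, among the compounds shown here, no step among compound 1, compound 2 and compound 3 can be read, since all three values are limits of the assay: the limit of > 100000 nM in this assay, at which 3 of the 3 values shown sit. Where the true values of these compounds lie, and whether either aromatic change moves them, stays open.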